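Working notes: from compound 2 to compound 3

A few compounds are considered here, and "the series" means these few. Any claim that something is new, unique, unknown or untested is made for them only; others in the source may bear on it.

Measured so far:
compound 1 `O=C(CSc1nc(Nc2ccccc2)c2ccccc2n1)Nc1ccc(C(F)(F)F)cc1` — 11700 nM
compound 2 `C=CC(=O)Nc1cccc(NC(=O)CSc2nc(Nc3ccccc3Cl)c3ccccc3n2)c1` — 10000 nM

In a functional assay on NCI-H1975 cells (Homo sapiens) for inhibition, read by MTT assay, with a stated time of 72 h (a lower number here means a stronger inhibitor, a higher number a weaker inhibitor), compound 1 gives 11700 nM and compound 2 gives 10000 nM. Compound 2 holds the lower of the two numbers, but its gap to compound 1 lies within the scatter, so no order between them is claimed. Compound 3 `C=CC(=O)Nc1cccc(NC(=O)CSc2nc(Nc3ccc(Br)cc3)c3ccccc3n2)c1` differs from compound 2 by 4-bromophenyl in place of 2-chlorophenyl on a nitrogen on an aromatic ring. Among the compounds with values here, no measured pair shows this kind of change, so its size is unknown; in this assay a step no larger than the scatter is expected, in no fixed direction. Compound 3 is therefore estimated at 10000 nM, with a range from 3000 nM to 33000 nM. The estimated step is no change at the digits printed from compound 2 to compound 3 (within the scatter).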

Compound 3, half-maximal inhibitory concentration: 6280 nM
Compound 3: the middle estimate sits 1.6-fold (0.20 log units) above what was measured; the measured number falls inside the stated range.
By their numbers in this assay, from the lowest: compounds 3, 2 and 1 (each within the scatter of the next).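

In this assay, within the data shown here, 4-bromophenyl in place of 2-chlorophenyl on a nitrogen on an aromatic ring gives a 1.6-fold lower number from compound 2 to compound 3 (0.20 log units; within the scatter) and is the first single-place step. At this position, the two halogen-bearing phenyl groups are not told apart by this read-out, and no order is claimed. No available evidence bears on the reason for this result.

The step changes the halogen and its place on the ring together, so the two remain unseparated. Also open, going by these compounds, is how 4-chlorophenyl, or a phenyl carrying an amine or a carboxylic acid, would read at this position.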